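A few compounds are considered here, and "the series" means these few. Any claim that something is new, unique, unknown or untested is made for them only; others in the source may bear on it.

Of the compounds shown here, two sharing one core have been measured so far, compound 1 `CNc1nccc(N2CC[C@H](NC(=O)Nc3ccc(CN(C)C)c(C(F)(F)F)c3)C2)n1` and compound 2 `CNc1nccc(N2CC[C@H](NC(=O)Nc3cc(OC)cc(OC)c3)C2)n1`. In an ADME assay on a cell-free system (plasma, Mus musculus) for protein binding, compound 1 gives 87.8% and compound 2 gives 96.9%. Compound 1 therefore leaves more of itself free than compound 2, and the gap lies beyond the usual scatter. Compound 3 `CNc1nccc(N2CC[C@H](NC(=O)Nc3ccc(Cl)c(C(F)(F)F)c3)C2)n1` keeps the core of compound 1 but carries chloro in place of (dimethylamino)methyl on an aromatic carbon. Among the measured compounds shown here, no measured pair shows this exact change, so the evidence is thin. Compound 2 also has no (dimethylamino)methyl group and gives 96.9%, so a step towards more binding, beyond the scatter, is expected. The estimated step is a 4.9-fold lower unbound fraction from compound 1 to compound 3 (0.69 log units; beyond the scatter). In this assay, compound 3 is estimated at 97.5%, within an expected range from 94% to 99.5%.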

Compound 3, plasma protein binding: 99.8%
The estimate for compound 3 lay 13-fold (1.10 log units) (unbound fraction) above the measured number; measured number above the stated range.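

In this assay, among the compounds shown here, the single change of (dimethylamino)methyl to chloro, on the aromatic carbon ortho to a trifluoromethyl group and para to a large group, produces a 61-fold lower unbound fraction from compound 1 to compound 3 (1.79 log units; beyond the scatter) with the rest of the molecule untouched. For the compounds shown here, compound 1 and compound 2 differ in more than one place, so only this pair ties a change in binding to this one position, and it shows that the position can move the read-out by a large amount. Nothing measured here explains why the step is so large.

On these data alone, it remains open whether the step comes from losing (dimethylamino)methyl or from gaining chloro. A plain hydrogen, a methyl group or a morpholinylmethyl group on the same carbon would help to separate the two.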